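The compounds below may be only part of what the source reports. "The series", "measured", "known", "first", "only" and "open" are said of these compounds alone.

Measured in an ADME assay on MT4 cells (Homo sapiens) for cytotoxicity, read by MTT assay, with a stated time of 5 days; on this read-out lower numbers stand for higher toxicity in this test and higher numbers for lower toxicity in this test:
compound 1 `Cc1cc(C)cc(S(=O)(=O)c2c(C(=O)N[C@H]3CCN(Cc4ccccc4F)C3)[nH]c3ccc(Cl)cc23)c1` gives 215000 nM
compound 2 `Cc1cc(C)cc(S(=O)(=O)c2c(C(=O)N[C@H]3CCN(Cc4ccccc4C#N)C3)[nH]c3ccc(Cl)cc23)c1` gives > 228000 nM
compound 3 `Cc1cc(C)cc(S(=O)(=O)c2c(C(=O)N[C@H]3CCN(CC(N)=O)C3)[nH]c3ccc(Cl)cc23)c1` gives 28100 nM

The value for compound 2 is a limit of this assay and not a number (the limit of > 228000 nM in this assay, at which 1 of the 3 values shown sits). Compound 3 therefore holds the lowest of the two numbers; its nearest neighbour is compound 1, and the step is a 7.7-fold lower number from compound 1 to compound 3 (0.88 log units; beyond the scatter). Against compound 2 the step is an at least 8.1-fold lower number from compound 2 to compound 3 (0.90 log units; beyond the scatter). Between compounds 1 and 2 the step is an at least 1.0-fold higher number from compound 1 to compound 2 (0.02 log units; that floor lies within the scatter), which says nothing about order.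

Compound 4 `Cc1cc(C)cc(S(=O)(=O)c2c(C(=O)NS(=O)(=O)c3ccc(F)cc3F)[nH]c3ccc(Cl)cc23)c1` is not yet measured. The change from compound 3 is (2,4-difluorophenyl)sulfonyl in place of 1-(carbamoylmethyl)pyrrolidin-3-yl on an amide-type nitrogen. Both measured steps concern swaps on the saturated chain carbon bound to the amine nitrogen in the ring, and both place the carbamoyl form, compound 3, at the low end while the 2-fluorophenyl and 2-cyanophenyl forms sit higher. Within the data shown here, the step to compound 4 removes that whole group and puts a (2,4-difluorophenyl)sulfonyl on the amide-type nitrogen, which none of the measured steps covers. The expectation is a moderate rise toward the levels of compounds 1 and 2, carried with wide uncertainty, so compound 4 is expected at a 3.6-fold higher number from compound 3 to compound 4 (0.55 log units; beyond the scatter). The estimate for compound 4 in this assay is 100000 nM, between 30000 nM and 250000 nM.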

Compound 4, half-maximal cytotoxic concentration: 121000 nM
The estimate for compound 4 lay 1.2-fold (0.08 log units) below the measured number; measured number inside the range.
By their numbers in this assay, from the lowest: compound 3; then compounds 4 and 1 (each within the scatter of the next). At a limit, above all of these: compound 2.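

In this assay, among these compounds, the earlier steps varied only the group on the amine nitrogen of the five-membered ring, whereas this change replaces the whole 1-(carbamoylmethyl)pyrrolidin-3-yl on the amide-type nitrogen, giving a 4.3-fold higher number from compound 3 to compound 4 (0.63 log units; beyond the scatter). The low number of compound 3 therefore does not carry over to a (2,4-difluorophenyl)sulfonyl at this position, and the five-membered ring and its defined stereocentre are not required for a number of the height seen for compound 4. The measurements at hand give no reason for the size of this step.

The change removes the ring and the carbamoyl group and adds the sulfonyl and the fluorinated aromatic ring in a single move, so the shift cannot be assigned to any one of these parts. Still open, as far as these compounds go, is how this position behaves with a sulfonyl bearing a phenyl ring without fluorine, a methylsulfonyl, or a simple amine chain on the amide-type nitrogen, and whether a carboxylic acid in place of the whole amide would keep the number at this level.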